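Dimethoxyphenyl to Trimethoxyphenyl: One Added Methoxy

The source may hold more compounds than are shown below. What is called first, only, known or untested is meant among the compounds shown, and "the series" means these compounds.

Of the compounds shown here, two have been measured so far. Compound 1 `CCC(C)c1cc(C2C(C#N)=C(N)OC3=C2C(=O)CC(C)(C)C3)cc2cc(-c3cc(OC)c(OC)c(OC)c3)c(=O)oc12` and compound 2 `COc1ccc(-c2cc3cc(C4C(C#N)=C(N)OC5=C4C(=O)CC(C)(C)C5)cc(C(C)(C)C)c3oc2=O)cc1OC` share a core and differ in two places. In a functional assay on the whole organism (strain Swiss albino) with Mus musculus as the target, in the forced swim test, with a stated time of 5 min, at a dose of 0.5 mg/kg by the intraperitoneal route (a higher number here means more inhibition at the dose given (going by the name of the read-out), a lower number less inhibition), compound 1 gives 28.2%, and compound 2 gives 22.5%. Compound 2 has the lower of the two numbers, but its gap to compound 1 lies within the scatter of repeated measurements, so the two cannot be told apart.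

Compound 3 `COc1cc(-c2cc3cc(C4C(C#N)=C(N)OC5=C4C(=O)CC(C)(C)C5)cc(C(C)(C)C)c3oc2=O)cc(OC)c1OC` is the next step from compound 2: methoxy in place of hydrogen on an aromatic carbon. Cut one bond further out, the change reads 3,4-dimethoxyphenyl to 3,4,5-trimethoxyphenyl. Among the compounds with values here, no measured pair differs in only one place, so the size of such a step is not known. Compound 1 carries the 3,4,5-trimethoxyphenyl and gives 28.2%, within the scatter of compound 2. The step of a number 3.5 percentage points higher from compound 2 to compound 3 (within the scatter) is therefore expected to be none beyond the scatter. Compound 3 is estimated at 26%, with a range from 12% to 40%.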

Compound 3, a percentage reported as inhibition, in the whole organism at one dose (the size of the read-out at that dose, not a potency): 30.1%
Compound 3: the middle estimate sits 4.1 percentage points below what was measured; low and high end bracket the measured number.
By their numbers in this assay, from the lowest: compounds 2, 1 and 3 (each within the scatter of the next).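

Within the data shown here, compound 3 gives the first pairs that differ in only one place, so the size of a step can now be read rather than inferred. In this assay, adding the methoxy group that turns 3,4-dimethoxyphenyl into 3,4,5-trimethoxyphenyl gives a step (a number 7.6 percentage points higher from compound 2 to compound 3 (within the scatter)) that does not separate the two compounds, and tert-butyl in place of sec-butyl on an aromatic carbon gives a step (a number 1.9 percentage points higher from compound 1 to compound 3 (within the scatter)) that does not separate them either. Nothing shown here offers an explanation for either result.

On these data alone, it remains open whether a hydroxy group or an amine on that aromatic carbon, or a longer chain in place of the tert-butyl, would move the number beyond the scatter. Also open, as far as these compounds go, is whether either step would look the same at another dose.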